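Phenyl in Place of tert-Butyl on a Shared Core

The compounds below may be only part of what the source reports. "The series", "measured", "known", "first", "only" and "open" are said of these compounds alone.

The three measured compounds and their numbers:

Compound 1, `CC1CN=C(c2ccc(-c3noc(-c4ccc(Cl)c(Cl)c4)n3)cc2)N1` — in an assay for inhibition of Amine oxidase [flavin-containing] B (Homo sapiens), read by fluorescence and spectrophotometry, using microsomes, with stated times of 30 min and 20 min (a lower number here means a stronger inhibitor, a higher number a weaker inhibitor), compound 1 gives 160 nM.
Compound 2, `CC(C)(C)c1ccc(-c2noc(-c3ccc(C4=NCCN4)cc3)n2)cc1` — in this assay compound 2 gives 411 nM.
Compound 3, `COc1cccc(-c2noc(-c3ccc(C4=NCCN4)cc3)n2)c1` — in this assay compound 3 gives 216 nM.

Of the three, compound 2 carries the highest number, though only its gap to compound 1 lies beyond the scatter; compound 3 sits within the scatter of compound 2, so no order between those two can be claimed. Among the measured compounds shown here, the three compounds differ from one another in more than one place, so no single-point step among them is available.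

Compound 4, `c1ccc(-c2ccc(-c3noc(-c4ccc(C5=NCCN5)cc4)n3)cc2)cc1`, differs from compound 2 in one place: phenyl in place of tert-butyl on an aromatic carbon. For the measured compounds named here, no measured pair shows the effect of this particular exchange, so any expectation rests on the spread of the three known numbers alone. Given that spread, the step is expected to be small: the estimated step of a 1.4-fold lower number from compound 2 to compound 4 (0.14 log units; within the scatter) is not expected to exceed the scatter in either direction. Compound 4 is expected to give 300 nM, with a range from 120 nM to 800 nM.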

Compound 4, half-maximal inhibitory concentration: 47600 nM
Beside the measured number, compound 4's estimate is 160-fold (2.20 log units) below it; measured number outside the range, above it.
By their numbers in this assay, from the lowest: compounds 1, 3 and 2 (each within the scatter of the next, the first and the last beyond it); then compound 4.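

In this assay, among the compounds shown here, phenyl in place of tert-butyl gives a 120-fold higher number from compound 2 to compound 4 (2.06 log units; beyond the scatter), and this is the first step in the set that changes a single place. The earlier compounds shown here differ from one another in more than one place, so they could not show how much depends on this one substituent, on an aromatic carbon para to a large group. The position is clearly not indifferent to what stands on it: the two groups both have 0 hydrogen-bond donors, 0 hydrogen-bond acceptors and no net charge, yet they differ sharply in the read-out, while tert-butyl has 4 heavy atoms and no ring and phenyl has 6 heavy atoms and one six-membered aromatic ring. Nothing in the data given here explains why this step is so large.

With only these two groups compared at this place, the step cannot be assigned to the added ring or to the added heavy atoms. As far as these compounds go, how a cyclohexyl ring, an isopropyl group, a primary amine or a carboxylic acid would fare on the same carbon remains open, as does whether the same exchange would give a step of similar size on the core of compound 1.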